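Hydrazone aryl swap in a shared core: towards compound 4

This account rests on a few compounds, and the source may have more. Where it says the series, first, only, none or still open, it means among the compounds named here.

Three measured members share one core and differ only in the aryl group on the carbon with a double bond to nitrogen. Compound 1 `O=C(N/N=C/c1cccc(Cl)c1)c1cccnc1Nc1cccc(C(F)(F)F)c1` carries a 3-chlorophenyl there; in a functional assay on the whole organism (strain Wistar) for inhibition, with Rattus norvegicus as the target, read by paw edema, with a stated time of 30 min, at a dose of 10 mg/kg by the intraperitoneal route (a higher number here means more inhibition at the dose given (going by the name of the read-out), a lower number less inhibition), compound 1 gives 77.8%. Compound 2 `O=C(N/N=C/c1cccc(O)c1)c1cccnc1Nc1cccc(C(F)(F)F)c1` has a 3-hydroxyphenyl and in this assay compound 2 gives 67.5%. Compound 3 `O=C(N/N=C/c1ccc(O)cc1)c1cccnc1Nc1cccc(C(F)(F)F)c1` has a 4-hydroxyphenyl and in this assay compound 3 gives 59.3%.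

On these numbers compound 2 stands second highest of three. The step of a number 10.3 percentage points lower from compound 1 to compound 2 (beyond the scatter) is beyond the scatter, whereas a number 8.2 percentage points lower from compound 2 to compound 3 (within the scatter) is within it, so compound 2 and compound 3 cannot be ordered.

Compound 4 `O=C(N/N=C/c1ccncc1)c1cccnc1Nc1cccc(C(F)(F)F)c1` is the next member. The change from compound 2 is pyridin-4-yl in place of 3-hydroxyphenyl on a carbon with a double bond to nitrogen. Among the compounds with values here, no measured step involves a pyridin-4-yl, so the closest guides are a number 10.3 percentage points lower from compound 1 to compound 2 (beyond the scatter) and a number 8.2 percentage points lower from compound 2 to compound 3 (within the scatter), which show that swapping or moving the substituent on this aryl group gives at most modest changes in this assay. The hydroxy donor is lost while an acceptor remains, so a small downward drift or no change beyond the scatter is expected.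

For compound 4 in this assay the expected value is 63%, with a range of 50% to 76%, which would be a step of a number 4.5 percentage points lower from compound 2 to compound 4 (within the scatter) from compound 2.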

Compound 4, a percentage reported as inhibition, in the whole organism at one dose (the size of the read-out at that dose, not a potency): 68.1%
Beside the measured number, compound 4's estimate is 5.1 percentage points below it; measured number inside the range.
By their numbers in this assay, from the lowest: compounds 3, 2, 4 and 1 (each within the scatter of the next, the first and the last beyond it).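

Pyridin-4-yl is the first ring with a hetero atom on the carbon with a double bond to nitrogen, and in this assay it cannot be told apart from any of the three earlier aryl groups (a number 0.6 percentage points higher from compound 2 to compound 4 (within the scatter); a number 8.8 percentage points higher from compound 3 to compound 4 (within the scatter); a number 9.7 percentage points lower from compound 1 to compound 4 (within the scatter)). Pyridin-4-yl carries no hydrogen-bond donor, whereas 3-hydroxyphenyl and 4-hydroxyphenyl each carry one, so a hydroxy group on this aryl group is not needed for a reading in this range. Within the data shown here, compound 4 therefore does not split the series further: the only steps beyond the scatter remain those from compound 1 to the two hydroxyphenyl compounds, and compound 4 stands within the scatter of all three. Nothing available explains why these readings fall as they do.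

The compounds shown leave open whether a carboxylic acid or an amine on this aryl group, or a cyclohexyl ring in place of the aromatic ring, would stay within the same band. With readings at one dose only, they also leave open how these compounds would compare at other doses.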